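This account rests on a few compounds, and the source may have more. Where it says the series, first, only, none or still open, it means among the compounds named here.

Measured compounds:
Compound 1, `COc1ccc(/C=C/c2cc(OC)cc(OC)c2/C=C/C(=O)NC2CC2)cc1`: 8810 nM
Compound 2, `COc1ccc(/C=C/c2cc(OC)cc(OC)c2/C=C/C(=O)N2CCCCC2)cc1`: 10600 nM
Compound 3, `COc1ccc(/C=C/c2cc(OC)cc(OC)c2/C=C/C(=O)N2CCCC2)cc1`: 6350 nM

All three were tested in a functional assay on A549 cells (Homo sapiens) for inhibition, read by MTT assay, with a stated time of 48 h; a higher number here means a weaker inhibitor, a lower number a stronger inhibitor. They share one core and differ only in the group attached to the carbonyl carbon of the amide. Among the compounds with values here, compound 1 stands second highest of the three numbers, but its neighbours are close: the step of a 1.2-fold higher number from compound 1 to compound 2 (0.08 log units; within the scatter) and the step of a 1.4-fold lower number from compound 1 to compound 3 (0.14 log units; within the scatter) both lie within the scatter, as does a 1.7-fold lower number from compound 2 to compound 3 (0.22 log units; within the scatter), so on these data no compound can be called stronger or weaker than another.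

Compound 4, `COc1ccc(/C=C/c2cc(OC)cc(OC)c2/C=C/C(=O)NC(C)C)cc1`, has not yet been measured. It differs from compound 1 in one place: isopropyl in place of cyclopropyl on an amide-type nitrogen.

The measured steps that bear on this change are those at the same amide, a 1.2-fold higher number from compound 1 to compound 2 (0.08 log units; within the scatter) and a 1.4-fold lower number from compound 1 to compound 3 (0.14 log units; within the scatter), where the cyclopropylamino group was replaced by a ring-containing amine. Neither moved beyond the scatter. The present change, cyclopropyl for isopropyl, exchanges one small group without donors or acceptors for another, so no step beyond the scatter is expected in this assay. Compound 4 is therefore expected to give about 8500 nM, within a range from 4000 nM to 18000 nM. The expected step is a 1.0-fold lower number from compound 1 to compound 4 (0.02 log units; within the scatter).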

Compound 4, half-maximal inhibitory concentration: 2360 nM
Estimate against measurement, compound 4: 3.6-fold (0.56 log units) above; measured number outside the range, below it.
By their numbers in this assay, from the lowest: compound 4; then compounds 3, 1 and 2 (each within the scatter of the next).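

In this assay, the group on the amide-type nitrogen proves able to shift the number: isopropyl in place of cyclopropyl, a change that removes the ring, gives a 3.7-fold lower number from compound 1 to compound 4 (0.57 log units; beyond the scatter) even though both groups hold 3 carbon atoms and neither has hydrogen-bond donors or acceptors. Compound 4 also stands apart from the two compounds with a ring amine on the carbonyl carbon, with a 2.7-fold lower number from compound 3 to compound 4 (0.43 log units; beyond the scatter) and a 4.5-fold lower number from compound 2 to compound 4 (0.65 log units; beyond the scatter) while every step among compound 1, compound 2 and compound 3 stayed within the scatter. Nothing in the data shown accounts for this difference.

Still open, from the compounds shown here alone, is whether a straight propyl chain or a tert-butyl group on the amide-type nitrogen would give a number like that of compound 4. Also open, going by these compounds, is how an amine or a carboxylic acid at the end of a longer chain there would fare.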